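The compounds below may be only part of what the source reports. "The series", "measured", "known", "first", "only" and "open" are said of these compounds alone.

Measured so far in a functional assay on A2780 cells (Homo sapiens) for antiproliferative activity, read by resazurin assay, with a stated time of 72 h; a higher number here means a weaker inhibitor, a lower number a stronger inhibitor:

- compound 1 `NC(=O)c1cc2c(Cc3ccccc3)n[nH]c2cc1O`: "not determined" (no result reported)
- compound 2 `CN(C(=O)c1cc2c(Cc3ccccc3)n[nH]c2cc1O)c1ccco1`: 2500 nM
- compound 3 `CN(Cc1cccc(Cl)c1)C(=O)c1cc2c(Cc3ccccc3)n[nH]c2cc1O`: 5300 nM

Compound 3 has the highest number of the two values in this assay; its nearest neighbour is compound 2, with the step of a 2.1-fold higher number from compound 2 to compound 3 (0.33 log units; beyond the scatter), modest but beyond the scatter. Compound 1 gives no point of reference, as no result was reported.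

Compound 4 `COc1cccc(CN(C)C(=O)c2cc3c(Cc4ccccc4)n[nH]c3cc2O)c1OC` differs from compound 3 in one place: 2,3-dimethoxyphenyl in place of 3-chlorophenyl on a saturated chain carbon bound to an amide-type nitrogen. Among the measured compounds shown here, no measured step bears directly on this exchange. For the measured compounds named here, the only step in the set, a 2.1-fold higher number from compound 2 to compound 3 (0.33 log units; beyond the scatter), swaps the whole group on the amide-type nitrogen and is modest in size; it says nothing about trading one aryl group for another on the saturated chain carbon bound to that nitrogen. With so little to go on, the expected step is a 1.1-fold higher number from compound 3 to compound 4 (0.05 log units; within the scatter), that is, no change beyond the scatter, with wide uncertainty. Compound 4 is therefore estimated at 6000 nM in this assay, in a range from 2500 nM to 15000 nM.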

Compound 4, half-maximal inhibitory concentration: 4800 nM
Beside the measured number, compound 4's estimate is 1.3-fold (0.10 log units) above it, within the range that was stated.
By their numbers in this assay, from the lowest: compounds 2, 4 and 3 (each within the scatter of the next, the first and the last beyond it).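

In this assay, the aryl group on a saturated chain carbon bound to an amide-type nitrogen can go from 3-chlorophenyl to 2,3-dimethoxyphenyl with no shift beyond the scatter (a 1.1-fold lower number from compound 3 to compound 4 (0.04 log units; within the scatter)). The exchange replaces a chlorine-bearing ring with a larger one carrying hydrogen-bond acceptors, yet the read-out does not separate the two compounds. On this single pair, the position tolerates both aryl groups, and no measured evidence accounts for this.

Open, on these data alone, is whether an amine or a carboxylic acid on that aryl ring, or a longer chain in place of the saturated chain carbon, would move the number beyond the scatter. Also open, as far as these compounds go, is whether a plain phenyl or a pyridine ring at this position would match compound 3 and compound 4.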